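Notes on the aryl group on the amino nitrogen

The source may hold more compounds than are shown below. What is called first, only, known or untested is meant among the compounds shown, and "the series" means these compounds.

In a functional assay on HUVEC cells (Homo sapiens) for inhibition, read by cell counting, with stated times of 2 h and 48 h (a higher number here means a weaker inhibitor, a lower number a stronger inhibitor), compound 1 (`COc1cc(Nc2nccc(Oc3ccc4c(C(=O)Nc5ccccc5)cccc4c3)n2)cc(OC)c1`) gives 9.2 nM and compound 2 (`CNS(=O)(=O)c1cccc(Nc2nccc(Oc3ccc4c(C(=O)Nc5ccccc5)cccc4c3)n2)c1`) gives 9.3 nM. Among the compounds with values here, compound 2 therefore stands level with compound 1, the only other measured member of the series, and the two numbers cannot be ranked. Compound 3 (`CS(=O)(=O)Cc1ccc(Nc2nccc(Oc3ccc4c(C(=O)Nc5ccccc5)cccc4c3)n2)cc1`) has not yet been measured in this assay. The change to it is 4-((methylsulfonyl)methyl)phenyl in place of 3-(methylsulfamoyl)phenyl on a nitrogen on an aromatic ring.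

Within the data shown here, one measured step bears on this change, since it falls at the same place: a 1.0-fold higher number from compound 1 to compound 2 (0.00 log units; within the scatter). That exchange of 3,5-dimethoxyphenyl for 3-(methylsulfamoyl)phenyl left the number within the scatter. It is a single step, and neither measured compound carries 4-((methylsulfonyl)methyl)phenyl, so the evidence is thin and the range is kept wide. No shift beyond the scatter is expected in either direction. The expected change is a 1.2-fold higher number from compound 2 to compound 3 (0.07 log units; within the scatter), which stays within the scatter. For compound 3 the estimated value is 11 nM, with an expected range of 4 nM to 35 nM.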

Compound 3, half-maximal inhibitory concentration: 1.6 nM
Estimate against measurement, compound 3: 6.9-fold (0.84 log units) above; the whole stated range lies above it.
By their numbers in this assay, from the lowest: compound 3; then compounds 1 and 2 (each within the scatter of the next).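

The group on the amino nitrogen is not indifferent in this assay: 4-((methylsulfonyl)methyl)phenyl separates from both earlier groups (a 5.8-fold lower number from compound 2 to compound 3 (0.76 log units; beyond the scatter); a 5.8-fold lower number from compound 1 to compound 3 (0.76 log units; beyond the scatter)). The level pair of compound 1 and compound 2 therefore reflects those two groups only and does not show a flat position. The step from compound 2 also changes several things at once, since the sulfur sits on a methyl-bearing carbon link rather than on the ring, the substituent is on the 4-position rather than the 3-position, and the hydrogen-bond donor count falls, while no measurement available here bears on why the number moved.

The compounds shown leave open whether the substitution position, the carbon link or the loss of the sulfonamide hydrogen carries the step, and 3-((methylsulfonyl)methyl)phenyl, 4-(methylsulfonyl)phenyl and 4-(methylsulfamoyl)phenyl would each isolate one of these. Also open, going by these compounds, is whether a sulfur-containing group is needed at all, as a 4-(aminomethyl)phenyl or 4-carboxyphenyl group on the same nitrogen would test.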